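Swapping carboxy for hydroxymethyl on compound 2

The source may report more compounds than this note shows. Statements on the series, on what has been measured and on what is new or still open speak of the compounds shown alone.

Compound 1 `C/C(=N\OCC(N)=O)c1ccc(Cl)cc1` gives 24 mg/kg
Compound 2 `C/C(=N\OCC(=O)O)c1ccc(Cl)s1` gives 34 mg/kg

Compound 2 (34 mg/kg) lies within the usual scatter of compound 1 (24 mg/kg) in a functional assay on the whole organism for inhibition, with Rattus norvegicus as the target, read by paw edema, with stated times of 1 h and 3 h (a higher number here means that more compound is needed for the effect, a lower number that less compound is needed), and the two numbers cannot be told apart.

Compound 3 `C/C(=N\OCCO)c1ccc(Cl)s1` keeps the rest of compound 2 and changes one small part of the chain: hydroxymethyl in place of carboxy on a saturated chain carbon bound to an oxygen.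

For the measured compounds named here, no measured pair of compounds shows this change on its own, so there is little to go on, and the uncertainty is wide. The natural anchor is compound 2 (34 mg/kg), and no shift beyond the scatter is expected from it in this assay for this swap. The estimated change is a 1.2-fold higher number from compound 2 to compound 3 (0.07 log units; within the scatter) and it stays modest.

Compound 3 is expected at 40 mg/kg (range 15 mg/kg to 100 mg/kg).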

Compound 3, dose for half-maximal effect: 60 mg/kg
For compound 3 the middle estimate is 1.5-fold (0.18 log units) below the measured one; measured number inside the range.
By their numbers in this assay, from the lowest: compounds 1, 2 and 3 (each within the scatter of the next, the first and the last beyond it).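

In this assay, putting hydroxymethyl in place of carboxy on a saturated chain carbon bound to an oxygen gives a 1.8-fold higher number from compound 2 to compound 3 (0.25 log units; within the scatter), which is the only direct reading of this change among the compounds shown. Carboxy is therefore not shown to be needed at this place, since the two compounds cannot be told apart in this test. No other measurement here bears on what lies behind this step.

The compounds shown leave open whether an amine or a longer chain at this place would also fit this picture, as a single pair cannot establish a trend. Compound 1 differs from compound 3 in more than one place, so that pair says nothing about this change on its own.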